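The compounds below may be only part of what the source reports. "The series", "measured", "known", "first", "only" and "open" are said of these compounds alone.

Measured so far:
compound 1 `O=C(O)C(Sc1nc(Cl)cc(Nc2cccc(Cl)c2)n1)c1cccc2ccccc12`: 700 nM
compound 2 `CC(C)CCNc1cc(Cl)nc(SC(C(=O)O)c2cccc3ccccc23)n1`: 2500 nM

In an assay on isolated protein for inhibition of Polyunsaturated fatty acid 5-lipoxygenase (Homo sapiens) (a lower number here means a stronger inhibitor, a higher number a weaker inhibitor), compound 1 gives the lower of the two numbers, with compound 2 standing a 3.6-fold higher number from compound 1 to compound 2 (0.55 log units; beyond the scatter) away. That step replaced the 3-chlorophenyl on the nitrogen with isopentyl, a plain chain, and the number rose.

Compound 3 `O=C(O)C(Sc1nc(Cl)cc(NCCCc2ccccc2)n1)c1cccc2ccccc12` is the third member of this set, and its change from compound 1 is 3-phenylpropyl in place of 3-chlorophenyl on a nitrogen on an aromatic ring. Going by the values given here, as in the step to compound 2, the aromatic group sitting directly on the nitrogen gives way to a chain, so a higher number is the natural expectation; the chain now carries a phenyl ring at its end, which the data give no separate step for. Among the compounds with values here, the only relevant measured step is the modest rise from compound 1 to compound 2, so a rise of similar or somewhat smaller size is expected. Compound 3 is estimated at 1500 nM, within 600 nM to 4000 nM, an expected step of a 2.1-fold higher number from compound 1 to compound 3 (0.33 log units; beyond the scatter).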

Compound 3, half-maximal inhibitory concentration: 1800 nM
Estimate against measurement, compound 3: 1.2-fold (0.08 log units) below; measured number inside the range.
By their numbers in this assay, from the lowest: compound 1; then compounds 3 and 2 (each within the scatter of the next).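

In this assay a chain on the nitrogen again gives a higher number, and this time the six-membered aromatic ring is still present: 3-phenylpropyl in place of 3-chlorophenyl gives a 2.6-fold higher number from compound 1 to compound 3 (0.41 log units; beyond the scatter) so carrying that ring at the end of a chain does not match compound 1. Changing the end of the chain, with benzyl in place of isopropyl two bonds along from the nitrogen, gives a 1.4-fold lower number from compound 2 to compound 3 (0.14 log units; within the scatter) and so the two chain compounds cannot be told apart here. No measurement shown accounts for either step.

As far as these compounds go, whether a shorter link, such as benzyl or 2-phenylethyl on the nitrogen, would bring the number closer to that of compound 1 remains open. A plain phenyl on the nitrogen would show what the chlorine of the 3-chlorophenyl contributes.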